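A few compounds are considered here, and "the series" means these few. Any claim that something is new, unique, unknown or untested is made for them only; others in the source may bear on it.

Measured compounds in the series:

compound 1, `CC(=O)SCCC(CCCCC(=O)Nc1ccccc1)SC(C)=O`: 2.84%
compound 2, `CC(=O)SCCC(CCCCC(=O)Nc1ccc(Cl)cc1)SC(C)=O`: 3.07%
compound 3, `O=C(CCCCC(CCSC(=O)c1ccccc1)SC(=O)c1ccccc1)Nc1ccccc1`: "not active" (no number reported)

In a functional assay on Bel-7402 cells (Homo sapiens) for inhibition, read by MTT assay, with a stated time of 24 h, tested at 1 ug/mL (on this read-out lower numbers stand for less inhibition of growth and higher numbers for more inhibition of growth at the one concentration tested), compound 1 gives 2.84% and compound 2 gives 3.07%. The two share a core and differ only by chloro in place of hydrogen on an aromatic carbon; the step of a number 0.2 percentage points higher from compound 1 to compound 2 (within the scatter) is within the scatter, so the two values cannot be told apart. Compound 3 is reported in this assay as "not active" (no number reported), with no number given. The difference between the core of compound 3 and the core of compound 1 is not broken down here.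

Compound 4, `O=C(CCCCC(CCSC(=O)c1ccccc1)SC(=O)c1ccccc1)Nc1ccccc1Cl`, is not yet measured. It differs from compound 3 by chloro in place of hydrogen on an aromatic carbon. Among the compounds with values here, this is the same kind of change as the one from compound 1 to compound 2, but not the same: there the chloro stands para to a large group, here it stands ortho to a large group.

Within the data shown here, for compound 4 the step from compound 3 is expected to be small, since the only measured example of this kind of change, a number 0.2 percentage points higher from compound 1 to compound 2 (within the scatter), stayed within the scatter, and compound 3 itself is reported as "not active" (no number reported). Compound 4 is therefore expected to show little inhibition of growth in this assay, estimated at 3%, with a likely range from 0% to 12%. There is a real chance that compound 4, like compound 3, is reported only as not active without a number.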

Compound 4, percent growth inhibition at one concentration: 7.37%
Compound 4: the middle estimate sits 4.4 percentage points below what was measured; the measured number falls inside the stated range.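

Within the data shown here, compound 3 has no number in this assay and compound 4 gives 7.37% there, so no step between the two can be read. The compounds shown leave open whether phenyl to 2-chlorophenyl alters growth inhibition on the core of compound 3, and whether the place of the chloro on the ring matters. No evidence at hand bears on this result.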